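The compounds below may be only part of what the source reports. "The series", "measured", "known", "first", "only" and "open" are said of these compounds alone.

Of the compounds shown here, three built on a shared core have been tested in a functional assay on L1210 cells (Mus musculus) for inhibition, read by cell counting, with a stated time of 2 days; a higher number here means a weaker inhibitor, a lower number a stronger inhibitor. Compound 1 `C=C(Br)C(=O)Nc1cccc(-c2cn3nc(-c4ccc(OCC)cc4)sc3n2)c1` gives 790 nM, compound 2 `C=C(Br)C(=O)Nc1cccc(-c2cn3nc(Cc4cccc(OC)c4)sc3n2)c1` gives 2000 nM, and compound 3 `C=C(Br)C(=O)Nc1cccc(-c2cn3nc(-c4ccc(Cl)cc4)sc3n2)c1` gives 1400 nM. Compound 3 stands second highest of these three numbers: its nearest neighbour is compound 2, separated by a 1.4-fold lower number from compound 2 to compound 3 (0.15 log units; within the scatter), and its furthest is compound 1, separated by a 1.8-fold higher number from compound 1 to compound 3 (0.25 log units; within the scatter), so both gaps sit within the usual scatter. The only measured gap beyond the scatter is a 2.5-fold higher number from compound 1 to compound 2 (0.40 log units; beyond the scatter), and even that is modest.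

Compound 4 `C=C(Br)C(=O)Nc1cccc(-c2cn3nc(-c4cccs4)sc3n2)c1` has not yet been measured. It differs from compound 3 in one place: thiophen-2-yl in place of 4-chlorophenyl on an aromatic carbon. All three measured steps change the group at this same aromatic carbon, and only the swap of 4-ethoxyphenyl for 3-methoxybenzyl moved the number beyond the scatter; chloro in place of ethoxy, and 4-chlorophenyl in place of 3-methoxybenzyl, did not. A change at this position is therefore expected to give no more than a small step in this assay, in either direction. For compound 4 the estimate is 1500 nM, with a range from 600 nM to 3500 nM. The expected step from compound 3 is a 1.1-fold higher number from compound 3 to compound 4 (0.03 log units; within the scatter), which is expected to remain within the scatter.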

Compound 4, half-maximal inhibitory concentration: 170 nM
Beside the measured number, compound 4's estimate is 8.8-fold (0.95 log units) above it, outside the stated range (below it).
By their numbers in this assay, from the lowest: compound 4; then compounds 1, 3 and 2 (each within the scatter of the next, the first and the last beyond it).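

Among the compounds shown here, this position is far more sensitive than the earlier compounds suggested: in this assay, thiophen-2-yl brings an 8.2-fold lower number from compound 3 to compound 4 (0.92 log units; beyond the scatter) and a 4.6-fold lower number from compound 1 to compound 4 (0.67 log units; beyond the scatter) as well as a 12-fold lower number from compound 2 to compound 4 (1.07 log units; beyond the scatter) and so makes compound 4 the strongest inhibitor of the four. The earlier groups at this aromatic carbon, all built on a six-membered carbon ring, gave steps that were small or within the scatter, so the new result shows that a five-membered aromatic ring with sulfur can sit here and give a much lower number. No measurement shown here explains why this exchange has such an effect.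

Thiophen-2-yl differs from 4-chlorophenyl in ring size, in carrying sulfur and in lacking chlorine, so these compounds cannot show which of those differences matters. Unsubstituted phenyl would address the loss of chlorine without changing the ring size, while furan-2-yl, with oxygen in place of sulfur, would test whether the gain depends on sulfur or holds for a five-membered aromatic ring more generally.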